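This account rests on a few compounds, and the source may have more. Where it says the series, first, only, none or still open, it means among the compounds named here.

Working notes on the piperidine sulfonyl series, read in a functional assay on MIA PaCa-2 cells (Homo sapiens) for inhibition, read by MTT assay, with a stated time of 7 days; on this read-out higher numbers stand for weaker inhibition and lower numbers for stronger inhibition.

Compound 2 `CCOC(=O)[C@@H]1CCCN(S(=O)(=O)c2ccc(S(=N)(=O)N(CC)CC)cc2)C1` gives 2600 nM in this assay. Of the three numbers in hand this is the second highest. Compound 3 `CCN(CC)S(=O)(=O)c1ccc(S(=O)(=O)N2CCC[C@@H](c3cc(C)no3)C2)cc1` gives 4900 nM in this assay, which sits within the scatter of compound 2, so no order between the two is claimed. Compound 1 `CC(C)c1noc(N2CCN(C(=O)[C@@H]3CCCN(S(=O)(=O)c4ccc(S(=O)(=O)C5CCC5)cc4)C3)CC2)n1` gives 70 nM in this assay, a far lower number, beyond the scatter of compound 2.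

Compound 4 `CCCN(CC)S(=O)(=O)c1ccc(S(=O)(=O)N2CCC[C@@H](C(=O)OCC)C2)cc1` has not been measured in this assay. Relative to compound 2 the change is a group of 9 heavy atoms (5 carbon, 1 nitrogen, 2 oxygen, 1 sulfur; no ring) in place of a group of 8 heavy atoms (4 carbon, 2 nitrogen, 1 oxygen, 1 sulfur; no ring), on an aromatic carbon. For the measured compounds named here, no measured pair isolates this change. The closest reference is compound 3, which carries a sulfamoyl of the same kind and gives 4900 nM in this assay. On that basis no step beyond the scatter is expected, with the step from compound 2 to compound 4 estimated as a 1.3-fold higher number from compound 2 to compound 4 (0.13 log units; within the scatter) in this assay. Compound 4 is expected to give about 3500 nM in this assay, within a range of 1200 nM to 10000 nM.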

Compound 4, half-maximal inhibitory concentration: 300 nM
Beside the measured number, compound 4's estimate is 12-fold (1.07 log units) above it; the measured number lies below the stated range.
By their numbers in this assay, from the lowest: compound 1; then compound 4; then compounds 2 and 3 (each within the scatter of the next).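

In this assay the swap to ethyl(propyl)sulfamoyl, on an aromatic carbon para to a large group, gives an 8.7-fold lower number from compound 2 to compound 4 (0.94 log units; beyond the scatter) and leaves the rest of the molecule unchanged, so this position does affect the read-out. The earlier compounds shown here held no pair differing in one place and could not show this. The swap removes the hydrogen-bond donor of the leaving group and adds to the heavy-atom count, and no measurement in hand explains the step.

A single step cannot separate the loss of that donor from the change in the alkyl groups on the sulfamoyl nitrogen. On these data alone, how a dipropylsulfamoyl or a dimethylsulfamoyl at this place would read, and whether the step carries over to the core of compound 1, remains open.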